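The source may report more compounds than this note shows. Statements on the series, on what has been measured and on what is new or still open speak of the compounds shown alone.

Compound 1 `CCOc1ccc(CCCN2CC=C(CCC(=O)NO)C2=O)cc1` carries an ethoxy group on its outer ring, and in a functional assay on HCT-15 cells (Homo sapiens) for inhibition, read by sulforhodamine B assay (a higher number here means a weaker inhibitor of growth, a lower number a stronger inhibitor of growth), compound 1 gives 5100 nM. Compound 2 `O=C(CCC1=CCN(Cc2cccc(Br)c2)C1=O)NO` gives 4720 nM in this assay, and the two numbers sit within the usual scatter of each other, so compound 1 and compound 2 cannot be told apart on this evidence. Compound 3 `N#Cc1cccc(CN2CC=C(CCC(=O)NO)C2=O)c1` gives only a limit in this assay, > 10000 nM, rather than a number. For the measured compounds named here, the single step measured between structures that differ in one place, an at least 2.1-fold higher number from compound 2 to compound 3 (0.32 log units; beyond the scatter), is known only as a bound because its end point is a limit (the limit of > 10000 nM in this assay, at which 1 of the 3 values shown sits), and it concerns a change to a different group than the one considered here.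

Compound 4 `Cc1ccc(CCCN2CC=C(CCC(=O)NO)C2=O)cc1` differs from compound 1 by methyl in place of ethoxy on an aromatic carbon. Going by the values given here, no measured step speaks to this change, so no movement beyond the scatter is expected. The estimate for compound 4 in this assay is 5500 nM, with a range from 2500 nM to 12000 nM. That amounts to an expected step of a 1.1-fold higher number from compound 1 to compound 4 (0.03 log units; within the scatter), which is expected to stay within the scatter.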

Compound 4, concentration for 50% growth inhibition: 5100 nM
For compound 4 the middle estimate is 1.1-fold (0.03 log units) above the measured one, within the range that was stated.
By their numbers in this assay, from the lowest: compounds 2, 1 and 4 (each within the scatter of the next). At a limit, above all of these: compound 3.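

Putting methyl in place of ethoxy on an aromatic carbon, para to a large group, gives no change at the digits printed from compound 1 to compound 4 (within the scatter) in this assay. Ethoxy brings 3 heavy atoms and 1 hydrogen-bond acceptor, methyl brings 1 heavy atom and 0 hydrogen-bond acceptors, so at this position, in this pair, that difference leaves growth inhibition unchanged within the scatter, something the earlier compounds could not show, since their only measured step concerned cyano in place of bromo. Nothing in the evidence at hand bears on this result.

The compounds shown leave open whether an amine, a carboxylic acid or a longer alkoxy chain on this same carbon would also leave the number in place. They also leave open what a plain hydrogen at this position would give.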